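Cyclopentyl for cyclohexyl on the carbonyl: series notes

This account rests on a few compounds, and the source may have more. Where it says the series, first, only, none or still open, it means among the compounds named here.

Of the compounds shown here, two have been measured in a physicochemical assay for lipophilicity, read by HPLC, measured as chromatographic lipophilicity, at pH 7.4; on this read-out lower numbers stand for lower lipophilicity and higher numbers for higher lipophilicity. Compound 1 `O=C(C1CCCCC1)N1N=CCC1c1ccccc1` gives 5.9 and stands highest of the two numbers; compound 2 `CC(C)(C)C(=O)N1N=CCC1c1cc[nH]n1` gives the lower value, 2.7. Compound 3 `O=C(C1CCCC1)N1N=CCC1c1ccccc1` has not yet been measured in this assay. It differs from compound 1 by cyclopentyl in place of cyclohexyl on a carbonyl carbon. Within the data shown here, no step between measured compounds covers this change. The expected step of a number 0.40 log units lower from compound 1 to compound 3 (beyond the scatter) is small and downward, at about the edge of the scatter. Compound 3 is therefore estimated at 5.5 in this assay, with a range from 5.1 to 5.9.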

Compound 3, distribution coefficient: 5.4
The estimate for compound 3 lay 0.10 log units above the measured number; measured number inside the range.
By their numbers in this assay, from the lowest: compound 2; then compound 3; then compound 1.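

At this position, on a carbonyl carbon whose other neighbour is an amide-type nitrogen in a ring, this assay gives the series its first step between compounds differing in one place: a number 0.50 log units lower from compound 1 to compound 3 (beyond the scatter) for a modest change. The read-out therefore responds to exchanging one all-carbon ring for another while the core of compound 1 stays the same. Nothing available bears on the origin of this step.

Going by these compounds, whether cyclobutyl or an open chain such as n-pentyl would move the number further remains open. So does whether the same step would hold on the core of compound 2.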